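A Repeated Pyridyl Shift Carried Onto Compound 3

The source may hold more compounds than are shown below. What is called first, only, known or untested is meant among the compounds shown, and "the series" means these compounds.

Three compounds have been measured in a functional assay on MCF7 cells (Homo sapiens) for inhibition, with a stated time of 96 h; a higher number here means a weaker inhibitor, a lower number a stronger inhibitor:

Compound 1, `COc1cc(C(=O)c2cn(-c3cccc(C)c3)cc2-c2cccnc2)cc(OC)c1OC`: 52 nM
Compound 2, `COc1cc(C(=O)c2cn(-c3cccc(C)c3)cc2-c2ccncc2)cc(OC)c1OC`: 65 nM
Compound 3, `COc1cc(C(=O)c2cn(-c3ccc(C)cc3)cc2-c2cccnc2)cc(OC)c1OC`: 19 nM

Compound 1 and compound 2 differ by pyridin-4-yl in place of pyridin-3-yl on an aromatic carbon, and this change gave a 1.3-fold higher number from compound 1 to compound 2 (0.10 log units; within the scatter). Compound 1 and compound 3 differ by 4-methylphenyl in place of 3-methylphenyl on an aromatic nitrogen, which gave a 2.7-fold lower number from compound 1 to compound 3 (0.44 log units; beyond the scatter). Compound 3 therefore carries the lowest number of the three, and its separation from compound 1 and from compound 2 is beyond the scatter in both cases, so it is the strongest inhibitor in this set.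

Compound 4, `COc1cc(C(=O)c2cn(-c3ccc(C)cc3)cc2-c2ccncc2)cc(OC)c1OC`, has not yet been measured. It differs from compound 3 by pyridin-4-yl in place of pyridin-3-yl on an aromatic carbon. Going by the values given here, this is the same kind of change as the one from compound 1 to compound 2; the two cores differ by 4-methylphenyl in place of 3-methylphenyl on an aromatic nitrogen, so around the place of the change the ring atom two ring bonds away bears a 4-methylphenyl group in compound 3 and compound 4 and a 3-methylphenyl group in compound 1 and compound 2.

Among the compounds with values here, the one earlier instance of this change gave a 1.3-fold higher number from compound 1 to compound 2 (0.10 log units; within the scatter), a step within the scatter. On that basis compound 4 is expected to sit near compound 3, with an estimated step of a 1.3-fold higher number from compound 3 to compound 4 (0.12 log units; within the scatter). For compound 4 in this assay the estimate is 25 nM, expected to fall between 12 nM and 55 nM.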

Compound 4, half-maximal inhibitory concentration: 9 nM
Beside the measured number, compound 4's estimate is 2.8-fold (0.44 log units) above it; the whole stated range lies above it.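

In this assay, pyridin-4-yl in place of pyridin-3-yl on the core of compound 3 gave a 2.1-fold lower number from compound 3 to compound 4 (0.32 log units; beyond the scatter), a step beyond the scatter where the earlier one was not, yet the two steps cannot be told apart: the same change on two cores in this assay, a 1.3-fold higher number (0.10 log units; within the scatter) from compound 1 to compound 2 and a 2.1-fold lower number (0.32 log units; beyond the scatter) from compound 3 to compound 4, 2.6-fold (0.42 log units) apart, within the scatter of two such steps. The change from 3-methylphenyl to 4-methylphenyl on an aromatic nitrogen, read on the core of compound 2, gave a 7.2-fold lower number from compound 2 to compound 4 (0.86 log units; beyond the scatter), the same direction as its earlier instance, and here too the two steps cannot be told apart: the same change on two cores in this assay, a 2.7-fold lower number (0.44 log units; beyond the scatter) from compound 1 to compound 3 and a 7.2-fold lower number (0.86 log units; beyond the scatter) from compound 2 to compound 4, 2.6-fold (0.42 log units) apart, within the scatter of two such steps. Going by these compounds alone, this shows that both changes can be compared across these two cores without a demonstrated dependence on the core, and that the methylphenyl change lowered the number in both pairs, but with only one pair per core it does not show that either step is truly the same on both cores, nor does it exclude a modest dependence.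

The compounds shown leave open whether these steps would hold with a different group on the ring nitrogen, such as a chloro-substituted phenyl or a longer alkyl chain. They also leave open what an amine or a carboxylic acid on the pyridine ring would do to the number in this assay.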